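More methoxy groups on one aryl ring: expected growth inhibition

The source may hold more compounds than are shown below. What is called first, only, known or untested is meant among the compounds shown, and "the series" means these compounds.

Compound 1, `COc1cc(/C=C/C(=O)/C=C/c2ccccc2)ccc1OCc1cn(CCCOc2cc(=O)oc3ccccc23)nn1`: 45%
Compound 2, `COc1ccccc1/C=C/C(=O)/C=C/c1ccc(OCc2cn(CCOc3cc(=O)oc4ccccc34)nn2)c(OC)c1`: 70%
Compound 3, `COc1cc(/C=C/C(=O)/C=C/c2cc(OC)c(OC)c(OC)c2)ccc1OCc1cn(CCCOc2cc(=O)oc3ccccc23)nn1`: 76%

In a functional assay on HCT-116 cells (Homo sapiens) for inhibition, read by sulforhodamine B assay, with a stated time of 48 h, tested at 50 uM (on this read-out lower numbers stand for less inhibition of growth and higher numbers for more inhibition of growth at the one concentration tested), compound 2 lies well above compound 1, beyond the scatter, while its gap to compound 3 is within the scatter. Compound 4, `COc1ccc(/C=C/C(=O)/C=C/c2ccc(OCc3cn(CCOc4cc(=O)oc5ccccc45)nn3)c(OC)c2)cc1OC`, has not yet been measured. It differs from compound 2 in one place: 3,4-dimethoxyphenyl in place of 2-methoxyphenyl on a double-bonded chain carbon bound to a double-bonded chain carbon. Among the compounds with values here, the one measured step that bears on this is a number 31 percentage points higher from compound 1 to compound 3 (beyond the scatter), where methoxy groups were added to the same ring. Compound 2 already carries one methoxy group and already sits close to compound 3 in this assay, so only a small further rise, within the scatter, is expected: a number 4 percentage points higher from compound 2 to compound 4 (within the scatter). Compound 4 is therefore estimated at 74%, with a range from 60% to 86%.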

Compound 4, percent growth inhibition at one concentration: 82%
For compound 4 the middle estimate is 8 percentage points below the measured one; low and high end bracket the measured number.
By their numbers in this assay, from the lowest: compound 1; then compounds 2, 3 and 4 (each within the scatter of the next, the first and the last beyond it).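

In this assay, this position on the double-bonded chain carbon still responds when its aryl ring already carries a methoxy group: 3,4-dimethoxyphenyl in place of 2-methoxyphenyl gives a number 12 percentage points higher from compound 2 to compound 4 (beyond the scatter). The earlier step at this position started from plain phenyl, so a rise here is not confined to that unsubstituted ring. No measurement shown gives a reason for this rise.

This change alters both the number and the placing of the methoxy groups, and the compounds shown cannot separate the two. On these data alone, whether an amine or a carboxylic acid on this ring would keep the growth inhibition also stays open.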